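Amide variation within a shared core, inhibition at one concentration

A few compounds are considered here, and "the series" means these few. Any claim that something is new, unique, unknown or untested is made for them only; others in the source may bear on it.

In an assay on isolated protein for inhibition of aldehyde dehydrogenase 1A1 (Homo sapiens), read by spectrophotometry, tested at 10 uM (a lower number here means less inhibition, a higher number more inhibition at the concentration tested (going by the name of the read-out)), compound 1 `Cc1cccc(Cn2c(OC3CCN(C(=O)c4ccco4)CC3)nc3ccccc32)c1` gives 68.3%, compound 2 `Cc1cccc(Cn2c(CN3CCN(C(=O)C4CCCC4)CC3)nc3ccccc32)c1` gives 67.5% and compound 3 `O=C(C1CC1)N1CCN(Cc2nc3ccccc3n2Cc2ccccc2F)CC1` gives 40.7%. Compound 2 thus stands second highest of the three; its gap to compound 1 lies within the scatter, its gap to compound 3 beyond it. Compound 4 `Cc1cccc(Cn2c(CN3CCN(C(=O)c4cccnc4)CC3)nc3ccccc32)c1` is not yet measured. It differs from compound 2 in one place: pyridin-3-yl in place of cyclopentyl on a carbonyl carbon, cyclopentylcarbonyl becoming (pyridin-3-yl)carbonyl. Among the measured compounds shown here, no measured pair shows this change, so the expectation rests on the spread of the three values alone. In this assay a step from compound 2 to compound 4 of about a number 9.5 percentage points lower from compound 2 to compound 4 (within the scatter) is expected, downward and likely within the scatter. Compound 4 is estimated at 58%, with a range from 32% to 80%.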

Compound 4, a percentage reported as inhibition, at one concentration (the size of the read-out at that concentration, not a potency): 24.5%
Compound 4: the middle estimate sits 33.5 percentage points above what was measured; measured number outside the range, below it.
By their numbers in this assay, from the lowest: compound 4; then compound 3; then compounds 2 and 1 (each within the scatter of the next).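

The group on this carbonyl carbon matters in this assay: pyridin-3-yl in place of cyclopentyl gives a number 43 percentage points lower from compound 2 to compound 4 (beyond the scatter) and supplies the series' first one-place comparison. With the rest of compound 2 kept, this single amide change is enough to move inhibition by a large step. Nothing available accounts for the drop.

Open, on these data alone, is whether the step follows the ring nitrogen or the aromatic ring itself. Phenyl on the same carbonyl carbon would separate the two, and pyridin-4-yl would test where the nitrogen sits.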